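Working notes: replacing a group on compound 1

The source may hold more compounds than are shown below. What is called first, only, known or untested is meant among the compounds shown, and "the series" means these compounds.

compound 1 `C=C(C)c1cccc(C(C)(C)NC(=O)Nc2ccc3cccnc3c2)c1` gives 0.0983 h
compound 2 `C/C(=N\O)c1cccc(C(C)(C)NC(=O)Nc2ccc(Cl)c([N+](=O)[O-])c2)c1` gives 0.183 h

In an in vitro ADME assay on microsomes from liver (Mus musculus) for metabolic stability (a lower number here means that the compound disappears faster, a higher number that the compound lasts longer), compound 1 and compound 2 lie within the scatter of each other, so compound 1 holds no distinct place. Compound 3 `C/C(=N\O)c1cccc(C(C)(C)NC(=O)Nc2ccc3cccnc3c2)c1` keeps the core of compound 1 and differs by a group of 4 heavy atoms (2 carbon, 1 nitrogen, 1 oxygen; no ring) in place of a group of 3 heavy atoms (3 carbon; no ring), on an aromatic carbon on an aromatic carbon, meta to a large group. Compound 2 carries the same entering group and gives 0.183 h on a different remainder. A small upward move is expected in this assay with a 1.4-fold higher number from compound 1 to compound 3 (0.15 log units; within the scatter) as the estimated size, not beyond the scatter. Compound 3 is estimated at 0.14 h (range 0.07 h to 0.3 h).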

Compound 3, half-life: 0.75 h
Beside the measured number, compound 3's estimate is 5.4-fold (0.73 log units) below it; the measured number lies above the stated range.
By their numbers in this assay, from the lowest: compounds 1 and 2 (each within the scatter of the next); then compound 3.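

At this aromatic carbon, meta to a large group, the number in this assay depends on the group carried: with the rest of compound 1 unchanged, the group of 4 heavy atoms in place of 1-methylethenyl gives a 7.6-fold higher number from compound 1 to compound 3 (0.88 log units; beyond the scatter) on the shared core. Among these compounds, this is the only single-place step, and the earlier pair could not show it. Nothing measured here bears on what lies behind the step.

On these data alone, it remains open whether an amine, a carboxylic acid or a longer chain at this position would give a similar number, and whether the same replacement gives a step of this size on a different remainder.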